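The source may report more compounds than this note shows. Statements on the series, on what has been measured and on what is new or still open speak of the compounds shown alone.

Compound 1, `Cc1ccc(S(=O)(=O)N2CCC(Cl)CC2)cc1`, in a functional assay on WiDr cells (Homo sapiens) for antiproliferative activity, read by sulforhodamine B assay, with a stated time of 48 h (on this read-out lower numbers stand for stronger inhibition of growth and higher numbers for weaker inhibition of growth), gives > 100000 nM, which is a limit of the assay and not a number.
Compound 2, `Cc1ccc(S(=O)(=O)N2CCC(Br)CC2)cc1`, in this assay gives > 100000 nM, which is likewise a limit of the assay and not a number.

Among the measured compounds shown here, compound 2 therefore stands at a limit in this assay, with no number of its own; the only other value shown is also a limit, both sitting at the limit of > 100000 nM in this assay, at which 2 of the 2 values shown sit. For the measured compounds named here, the one measured step, a step that the two limits leave unreadable from compound 1 to compound 2, is bromo in place of chloro on a saturated ring carbon, and the two limits leave its size unreadable.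

Compound 3, `Cc1ccc(S(=O)(=O)N2CC[C@@H](Br)C[C@@H]2c2ccccc2)cc1`, differs from compound 2 by phenyl in place of hydrogen on a saturated ring carbon. No measured step bears on this change, since the single step shown is unreadable and concerns a different position. The expectation for compound 3 in this assay can therefore rest only on the limit of compound 2 and the absence of any readable step. Compound 3 is estimated at 50000 nM, within 5000 nM to 200000 nM, so that the step of an at least 2.0-fold lower number from compound 2 to compound 3 (0.30 log units; that floor lies within the scatter) is expected to be uncertain and not readable in either direction beyond the scatter.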

Compound 3, concentration for 50% growth inhibition: 36000 nM
The estimate for compound 3 lay 1.4-fold (0.14 log units) above the measured number; the measured number falls inside the stated range.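

Of the three compounds shown, only compound 3 gives a number of its own in this assay, while compound 1 and compound 2 each stand at a limit of the assay: the limit of > 100000 nM in this assay, at which 2 of the 3 values shown sit.

Phenyl in place of hydrogen on a saturated ring carbon, next to the ring nitrogen and two ring bonds from the ring atom that bears a bromo group, gives an at least 2.7-fold lower number from compound 2 to compound 3 (0.44 log units; beyond the scatter), and with compound 2 resting on a limit this size is a floor and not a measured gap. This carbon, which holds only hydrogen in compound 2, therefore bears on growth inhibition in a way that the exchange of chloro for bromo could not show, as that step cannot be read.

As far as these compounds go, what remains open is whether this step belongs to phenyl as such, or would also follow from methyl, benzyl or a pyridine ring on the same carbon. The compounds shown also leave open what the bromo group contributes once phenyl is present, and whether chloro or a hydroxyl group on that ring carbon would give a similar number.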